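The compounds below may be only part of what the source reports. "The series", "measured", "known", "first", "only" and "open" are said of these compounds alone.

Values so far in a functional assay on the whole organism with Mus musculus as the target; a higher number here means that more compound is needed for the effect, a lower number that less compound is needed
Compound 1 `C[C@@H](NCc1ccc(OCc2cccs2)cc1)C(N)=O` gives 61.6 mg/kg
Compound 2 `C[C@@H](NCc1ccc(OCc2ccco2)cc1)C(N)=O` gives 116 mg/kg
Compound 3 `C[C@@H](NCc1ccc(OCc2ccoc2)cc1)C(N)=O` has no value yet

Among the measured compounds shown here, compound 2 stands within the scatter of compound 1, the only other measured compound. Compound 3 carries furan-3-yl in place of furan-2-yl on a saturated chain carbon bound to an oxygen on an aromatic ring. For the measured compounds named here, the only measured step at this place (a 1.9-fold higher number from compound 1 to compound 2 (0.27 log units; within the scatter)) stayed within the scatter, so no step beyond the scatter and no direction is expected in this assay here. The estimated change is a 1.2-fold lower number from compound 2 to compound 3 (0.06 log units; within the scatter) in size. For compound 3 the estimate is 100 mg/kg with an expected range from 50 mg/kg to 200 mg/kg for now.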

Compound 3, dose for half-maximal effect: 152 mg/kg
For compound 3 the middle estimate is 1.5-fold (0.18 log units) below the measured one, and the stated range covers the measured number.
By their numbers in this assay, from the lowest: compounds 1, 2 and 3 (each within the scatter of the next, the first and the last beyond it).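

In this assay, furan-3-yl in place of furan-2-yl gives a 1.3-fold higher number from compound 2 to compound 3 (0.12 log units; within the scatter) and so does not separate the two furan attachments at this position. Furan-3-yl in place of thiophen-2-yl gives a 2.5-fold higher number from compound 1 to compound 3 (0.39 log units; beyond the scatter) and is the only step at this place beyond the scatter, though a modest one. Nothing available bears on the reason for either step.

Open, going by these compounds, is whether thiophen-3-yl would stand with thiophen-2-yl or with furan-3-yl in this assay. Also open, on these data alone, is how a phenyl ring at this place would compare.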